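A few compounds are considered here, and "the series" means these few. Any claim that something is new, unique, unknown or untested is made for them only; others in the source may bear on it.

Of the compounds shown here, three have so far been measured in a functional assay on A549 cells (Homo sapiens) for cytotoxicity, with a stated time of 48 h; on this read-out higher numbers stand for weaker inhibition and lower numbers for stronger inhibition. Compound 1 `COc1cccc2c(=O)cc(/C=C/[S+](C)[O-])oc12` gives 2200 nM. Compound 2 `CC(C)C(=O)Oc1ccc2oc(/C=C/[S+](C)[O-])cc(=O)c2c1` gives 2400 nM. Compound 3 `Cc1c(/C=C/[S+](C)[O-])oc2ccccc2c1=O` gives 1500 nM. Compound 2 thus stands at the highest of the three numbers, yet its nearest neighbour, compound 1, and its furthest, compound 3, both lie within the usual scatter of it, so these three numbers do not separate the compounds from one another.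

Compound 4 `CC(C)Oc1ccc2oc(/C=C/[S+](C)[O-])cc(=O)c2c1` has not yet been measured. It differs from compound 2 at one place: isopropyl in place of isopropylcarbonyl on an oxygen on an aromatic ring The same difference, cut one bond further out, reads (isopropylcarbonyl)oxy to isopropoxy. Going by the values given here, no pair of the measured compounds differs in a single place, so no measured step bears directly on this change. What the three measured compounds do show is that rather different substitution on the shared core leaves the number in this assay within a narrow band, from compound 3 to compound 2. On that footing compound 4 is expected to remain in that band, with a step of a 1.2-fold lower number from compound 2 to compound 4 (0.08 log units; within the scatter) of no size beyond the scatter in either direction. Compound 4 is estimated at 2000 nM, with a range from 800 nM to 5000 nM.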

Compound 4, half-maximal inhibitory concentration: 1500 nM
Compound 4: the middle estimate sits 1.3-fold (0.12 log units) above what was measured; low and high end bracket the measured number.
By their numbers in this assay, from the lowest: compounds 3, 4, 1 and 2 (each within the scatter of the next).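

Going by these compounds alone, compound 4 supplies the first comparison in which only one place changes: in this assay, isopropyl in place of isopropylcarbonyl on an oxygen on an aromatic ring gives a 1.6-fold lower number from compound 2 to compound 4 (0.20 log units; within the scatter), with the series otherwise held constant. Within the data shown here, the change removes the carbonyl and its hydrogen-bond acceptor and takes the group from 5 heavy atoms to 3, yet this read-out does not separate (isopropylcarbonyl)oxy from isopropoxy at this position, so the carbonyl is not needed to keep the number in the band of the earlier compounds. Nothing measured on these compounds offers an account of why the number holds across this change.

The compounds shown leave open whether a free hydroxyl, an amine, a carboxylic acid or a longer alkoxy chain on this ring position would carry the number beyond the scatter in either direction. Among these compounds, with compound 2 and compound 4 as the only pair that differs in one place, it also stays open whether the same exchange would behave alike on a core carrying other substituents.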